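A few compounds are considered here, and "the series" means these few. Any claim that something is new, unique, unknown or untested is made for them only; others in the source may bear on it.

Values in a functional assay on HeLa cells (Homo sapiens) for inhibition, read by MTT assay, with a stated time of 72 h; a lower number here means a stronger inhibitor, a higher number a weaker inhibitor:
- Compound 1 `Clc1ccc(-c2nnc(SCCCN3CCN(c4nc5ccccc5o4)CC3)o2)cc1`: 101000 nM
- Compound 2 `Fc1ccc(-c2nnc(SCCCN3CCN(c4nc5ccccc5o4)CC3)o2)cc1`: 196000 nM
- Compound 3 `Oc1ccc(-c2nnc(SCCCN3CCN(c4nc5ccccc5o4)CC3)o2)cc1`: 99500 nM

Compound 2 has no clear place of its own among these three. Its two steps are a 1.9-fold higher number from compound 1 to compound 2 (0.29 log units; within the scatter) and a 2.0-fold lower number from compound 2 to compound 3 (0.29 log units; within the scatter), so it cannot be told apart from its neighbours. The third step, a 1.0-fold lower number from compound 1 to compound 3 (0.01 log units; within the scatter), is no larger.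

Compound 4 `O=C(NCc1nnc(SCCCN2CCN(c3nc4ccccc4o3)CC2)o1)c1ccccc1` differs from compound 2 by having benzamidomethyl in place of 4-fluorophenyl on an aromatic carbon. This is a far bigger change than any measured so far. The three measured steps only swap one group on an aromatic carbon, and none replaces the whole 4-fluorophenyl, so they are weak guides. Still, the shared core has stayed flat across them, as a 1.0-fold lower number from compound 1 to compound 3 (0.01 log units; within the scatter) shows, so no step beyond the scatter is expected in this assay, though this expectation is uncertain.

The expected step is a 1.5-fold lower number from compound 2 to compound 4 (0.18 log units; within the scatter).

Compound 4 is estimated at 130000 nM, with an expected range from 50000 nM to 300000 nM.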

Compound 4, half-maximal inhibitory concentration: 63900 nM
For compound 4 the middle estimate is 2.0-fold (0.31 log units) above the measured one, within the range that was stated.
By their numbers in this assay, from the lowest: compounds 4, 3, 1 and 2 (each within the scatter of the next, the first and the last beyond it).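

In this assay, going by these compounds alone, this is the first change on the aromatic carbon of the five-membered ring that gives a step beyond the scatter: benzamidomethyl in place of 4-fluorophenyl gives a 3.1-fold lower number from compound 2 to compound 4 (0.49 log units; beyond the scatter) as a modest step. The same swap gives a 1.6-fold lower number from compound 3 to compound 4 (0.19 log units; within the scatter) from 4-hydroxyphenyl and a 1.6-fold lower number from compound 1 to compound 4 (0.20 log units; within the scatter) from 4-chlorophenyl, both within the scatter, so compound 4 stands apart from compound 2 only, and the gain depends on which group leaves. The position therefore tolerates a larger group with an amide in place of a directly attached substituted phenyl ring, but no measurement here explains the step.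

Going by these compounds, it remains open whether an amine or a carboxylic acid at this position would move the number beyond the scatter from compound 4. It is also unclear whether the amide or the six-membered aromatic ring of benzamidomethyl accounts for the step from compound 2.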